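Adding a chlorine to a benzyl group on a cytotoxic series

A few compounds are considered here, and "the series" means these few. Any claim that something is new, unique, unknown or untested is made for them only; others in the source may bear on it.

Of the compounds shown here, three from this series have been tested in a functional assay on MDA-MB-231 cells (Homo sapiens) for cytotoxicity, read by MTT assay, with a stated time of 72 h; on this read-out lower numbers stand for stronger inhibition and higher numbers for weaker inhibition. Compound 1 `CC1CCN(Cc2ccc3nc(NC(=O)N/N=C/c4cn(Cc5ccc(Cl)cc5Cl)c5ccccc45)sc3c2)CC1` gives 3140 nM. Compound 2 `CC1CCN(Cc2ccc3nc(NC(=O)N/N=C/c4cn(Cc5ccccc5Cl)c5ccccc45)sc3c2)CC1` gives 1360 nM. Compound 3 `CCN(CC)Cc1ccc2nc(NC(=O)N/N=C/c3cn(Cc4ccccc4)c4ccccc34)sc2c1` gives 1470 nM; compound 3 and compound 2 carry different cores, and the difference between the two cores is not broken down here. Their values sit within the usual scatter of each other, so no order can be drawn between them.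

Compound 2 and compound 1 differ in one place only: chloro in place of hydrogen on an aromatic carbon. This change brought a 2.3-fold higher number from compound 2 to compound 1 (0.36 log units; beyond the scatter).

Compound 4 `CCN(CC)Cc1ccc2nc(NC(=O)N/N=C/c3cn(Cc4ccccc4Cl)c4ccccc34)sc2c1` is not yet measured. It differs from compound 3 by chloro in place of hydrogen on an aromatic carbon. This is the same kind of change as that from compound 2 to compound 1, but not the same: there the entering chloro sat meta to a chloro group and para to a large group, here it sits ortho to a large group, with no chloro already present.

Within the data shown here, compound 4 is expected to be close to compound 3, with a step of a 1.2-fold higher number from compound 3 to compound 4 (0.09 log units; within the scatter), because the only measured chloro step, a 2.3-fold higher number from compound 2 to compound 1 (0.36 log units; beyond the scatter), was modest and the surroundings differ. The estimate for compound 4 in this assay is 1800 nM, between 700 nM and 4500 nM.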

Compound 4, half-maximal inhibitory concentration: 900 nM
Beside the measured number, compound 4's estimate is 2.0-fold (0.30 log units) above it; the measured number falls inside the stated range.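

In this assay, the chloro step on the core of compound 3 does not repeat the one seen on the core of compound 2, and the two steps differ: the same change on two cores in this assay, a 2.3-fold higher number (0.36 log units; beyond the scatter) from compound 2 to compound 1 and a 1.6-fold lower number (0.21 log units; within the scatter) from compound 3 to compound 4, 3.8-fold (0.58 log units) apart, beyond the scatter of two such steps

Taken alone, a 1.6-fold lower number from compound 3 to compound 4 (0.21 log units; within the scatter) is too small to put the two compounds in order, and so is a 1.5-fold lower number from compound 2 to compound 4 (0.18 log units; within the scatter), where diethylamino replaces 4-methylpiperidin-1-yl. The result shows that a chloro step measured on one core cannot simply be carried over to the other, but it does not show that the core alone accounts for the gap: in compound 4 the chloro sits ortho to a large group with no chloro already present, whereas compound 2 already carries a chloro and takes its second at another place on the benzyl group.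

The compounds shown leave open whether a chloro entering at the same place would give matching steps on both cores. They also leave open how a fluoro or a methoxy group would compare at that place, or a morpholine in place of the diethylamino group.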